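Ring Partners on the Amine Nitrogen: Two Parallel Swaps

The source may hold more compounds than are shown below. What is called first, only, known or untested is meant among the compounds shown, and "the series" means these compounds.

Four compounds are set side by side in a functional assay on cells for agonist activity at C-X-C chemokine receptor type 4 (Homo sapiens), read by fluorescence and calcium flux, with a stated time of 90 s; a lower number here means that less compound is needed, a higher number that more compound is needed for the effect. Compound 1, `FC1(F)CCC(NCc2ccc(CN(C[C@H]3Cc4ccccc4CN3)[C@H]3CCCc4cccnc43)cc2)CC1`, carries a 4,4-difluorocyclohexyl group on an amine nitrogen. In this assay compound 1 does not reach a number at all; its value, > 30000 nM, is a limit of the assay. Compound 2, `c1ccc2c(c1)CN[C@@H](CN(Cc1ccc(CNC3CCOCC3)cc1)[C@H]1CCCc3cccnc31)C2`, is built from compound 1 by one change, (oxan-4-yl in place of 4,4-difluorocyclohexyl on an amine nitrogen). In this assay compound 2 likewise stops at a limit, > 30000 nM. The step that the two limits leave unreadable from compound 1 to compound 2 therefore cannot be sized, since (the limit of > 30000 nM in this assay, at which 3 of the 3 values shown sit).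

Compound 3, `FC1(F)CCC(NC/C=C/CN(C[C@H]2Cc3ccccc3CN2)[C@H]2CCCc3cccnc32)CC1`, keeps the 4,4-difluorocyclohexyl group but rests on a different core; the difference between the two cores of compound 3 and compound 1 is not broken down here. In this assay compound 3 again gives only a limit, > 30000 nM.

Compound 4, `C(=C/CN(C[C@H]1Cc2ccccc2CN1)[C@H]1CCCc2cccnc21)\CNC1CCOCC1`, is not yet measured. It stands to compound 3 as compound 2 stands to compound 1, the same change at the same place: oxan-4-yl in place of 4,4-difluorocyclohexyl on an amine nitrogen. What is expected of compound 4 rests only on that parallel and on (the limit of > 30000 nM in this assay, at which 3 of the 3 values shown sit), which puts every value shown at the limit. The step of a number no higher from compound 3 to compound 4 (the limit leaves the size open) is accordingly expected to be unreadable, as a step that the two limits leave unreadable from compound 1 to compound 2 was. For compound 4 the estimated value in this assay is 30000 nM, with a range of 10000 nM to 100000 nM, and most likely the assay will report only a limit.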

Compound 4, half-maximal effective concentration: > 30000 nM
Compound 4: only a limit was reported (the forecaster's own chance of this, stated with the estimate: 85%); the middle value sits exactly at the limit.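

In this assay compound 4 gives > 30000 nM, a limit of the assay and not a number. No step can be read from compound 3 to compound 4, just as none could be read from compound 1 to compound 2: the limit of > 30000 nM in this assay, at which 4 of the 4 values shown sit. The compounds shown leave open whether oxan-4-yl and 4,4-difluorocyclohexyl on the amine nitrogen differ at all in this assay on either core.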